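A Smaller Amide on a Weakly Antiproliferative Scaffold

This account rests on a few compounds, and the source may have more. Where it says the series, first, only, none or still open, it means among the compounds named here.

Among the compounds with values here, compound 2 `CCn1c(C(=O)N(CCC#N)CCC#N)ccc1C(CC)(CC)c1ccc(OCCC(O)(CC)CC)c(C)c1` is the only member of this set with an actual number in an ADME assay on L02 cells (Homo sapiens) for antiproliferative activity, read by MTT assay, with a stated time of 48 h; on this read-out lower numbers stand for stronger inhibition and higher numbers for weaker inhibition: compound 2 gives 37800 nM. Its neighbour compound 1 `CCn1c(C(=O)NCC#N)ccc1C(CC)(CC)c1ccc(OCCC(O)(CC)CC)c(C)c1` differs from it at the carbonyl carbon. In this assay compound 1 returns only a limit of the assay, > 50000 nM. Within the data shown here, the step of an at least 1.3-fold lower number from compound 1 to compound 2 (0.12 log units; that floor lies within the scatter) is therefore the sole measured step, and it rests on (the limit of > 50000 nM in this assay, at which 1 of the 2 values shown sits), so it fixes no direction with any confidence.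

Compound 3 `CCn1c(C(=O)N(C)CCO)ccc1C(CC)(CC)c1ccc(OCCC(O)(CC)CC)c(C)c1` is not yet measured. It differs from compound 2 as follows: a group of 5 heavy atoms (3 carbon, 1 nitrogen, 1 oxygen; no ring) in place of a group of 9 heavy atoms (6 carbon, 3 nitrogen; no ring), on a carbonyl carbon. Among the measured compounds shown here, the one measured step bears on it only loosely: it touches the same carbonyl carbon, but its size sits at the scatter floor and is anchored by a limit. For the measured compounds named here, no measured step thus predicts a move beyond the scatter in this assay. Compound 3 is estimated at 45000 nM, within 15000 nM to 120000 nM. The expected step of a 1.2-fold higher number from compound 2 to compound 3 (0.08 log units; within the scatter) is judged to lie within the scatter, with a real chance that compound 3 also returns only a limit.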

Compound 3, half-maximal inhibitory concentration: 2050 nM
Compound 3: the middle estimate sits 22-fold (1.34 log units) above what was measured, outside the stated range (below it).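

In this assay, the carbonyl carbon turns out to be a place where the amide group can move the read-out well beyond the scatter, which the earlier pair at this same carbon could not show: the measured change is an 18-fold lower number from compound 2 to compound 3 (1.27 log units; beyond the scatter). The comparison with compound 1 points the same way, with (2-hydroxyethyl)(methyl)amino in place of (cyanomethyl)amino giving an at least 24-fold lower number from compound 1 to compound 3 (1.38 log units; beyond the scatter). That second step is only a floor, as compound 1 gives a limit of the assay and not a number: the limit of > 50000 nM in this assay, at which 1 of the 3 values shown sits.

Because the whole amine part changes at once in each step, the compounds shown leave open whether the hydroxyl, the methyl or the departure of the nitrile-bearing group carries the effect, and a 2-methoxyethyl chain or a plain dimethylamino group on the same carbonyl carbon would begin to separate these: the limit of > 50000 nM in this assay, at which 1 of the 3 values shown sits. They also leave open how far the read-out follows chain length at this place, as a longer 3-hydroxypropyl chain would test.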